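Cytotoxicity notes: dimethylamino in place of benzofuranyl

This account rests on a few compounds, and the source may have more. Where it says the series, first, only, none or still open, it means among the compounds named here.

Compound 2 `c1ccc(-c2ccc(Cn3cncc3CNc3ccc(-c4cc5ccccc5o4)c(-c4ccccc4)c3)cc2)cc1` is the anchor of this step. In a toxicity assay on NIH3T3 cells (Mus musculus) for cytotoxicity, read by resazurin assay (on this read-out higher numbers stand for an effect only at larger amounts of compound and lower numbers for an effect already at smaller amounts), compound 2 gives > 10000 nM, which is a limit of the assay and not a number, sitting at the limit of > 10000 nM in this assay, at which 1 of the 3 values shown sits. Compound 1 `CC(C)c1cccc(NCc2cncn2Cc2ccccc2)c1` gives in this assay > 1000 nM, also a limit. Compound 3 `c1ccc(Cn2cncc2CNc2cccc(-c3ccncc3)c2)cc1` gives in this assay > 1000 nM, again a limit. Both of these sit at the limit of > 1000 nM in this assay, at which 2 of the 3 values shown sit. Among the measured compounds shown here, the only measured step, a step that the two limits leave unreadable from compound 1 to compound 3, is unreadable between limits and concerns a different change. Compound 4 `CN(C)c1ccc(NCc2cncn2Cc2ccc(-c3ccccc3)cc2)cc1-c1ccccc1` differs from compound 2 by dimethylamino in place of 1-benzofuran-2-yl on an aromatic carbon. For the measured compounds named here, no measured step bears on this change, and every value in hand is a limit. Compound 4 is therefore expected to show no step beyond the scatter, a step that the limit leaves unreadable from compound 2 to compound 4. The estimate for compound 4 is 15000 nM, ranging from 3000 nM to 60000 nM, most likely reported once more as a limit.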

Compound 4, half-maximal effective concentration: > 1000 nM
Compound 4 gave a limit, no number; the forecaster's own chance of this, stated with the estimate: 80%; the middle value lies beyond the limit too.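

In this assay compound 2 and compound 4 both stand as limits of the assay, so no step can be read between them. The compounds shown leave open whether dimethylamino in place of 1-benzofuran-2-yl changes cytotoxicity at all: none of them gives a number.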